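Ester Chain Length and Liver Microsome Stability

A few compounds are considered here, and "the series" means these few. Any claim that something is new, unique, unknown or untested is made for them only; others in the source may bear on it.

Compound 1 `CCCCc1nc(C(C)C)c(CC(=O)OC)c(=O)n1Cc1ccc(-c2ccccc2-c2noc(=O)[nH]2)cc1` gives 10.5% in an ADME assay on microsomes from liver (Homo sapiens) for metabolic stability, with a stated time of 30 min; a lower number here means that less of the compound is left, a higher number that more of the compound is left.
Compound 2 `CCCCOC(=O)Cc1c(C(C)C)nc(CCCC)n(Cc2ccc(-c3ccccc3-c3noc(=O)[nH]3)cc2)c1=O` gives 7.1% in this assay.
Compound 3 `CCCCc1nc(C)c(CC(=O)OC)c(=O)n1Cc1ccc(-c2ccccc2-c2noc(=O)[nH]2)cc1` gives 69.6% in this assay.

Compound 3 stands highest of the three; the step of a number 59.1 percentage points higher from compound 1 to compound 3 (beyond the scatter) sets it well apart from compound 1, and compound 2 lies further below still. Compound 4 `CCCCOC(=O)Cc1c(C)nc(CCCC)n(Cc2ccc(-c3ccccc3-c3noc(=O)[nH]3)cc2)c1=O` differs from compound 3 only by propyl in place of hydrogen on a saturated chain carbon bound to an oxygen next to a carbonyl group. Within the data shown here, one measured step bears on this change: the same swap gave a number 3.4 percentage points lower from compound 1 to compound 2 (within the scatter), a step within the scatter. Among the measured compounds shown here, no other pair speaks to it. Since that like change gave a number 3.4 percentage points lower from compound 1 to compound 2 (within the scatter), no movement beyond the scatter is expected in this assay. Compound 4 is therefore estimated at 65%, with a range from 45% to 85%. The expected step is a number 4.6 percentage points lower from compound 3 to compound 4 (within the scatter), within the scatter.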

Compound 4, percent of the compound remaining: 2.8%
Compound 4: middle estimate off by 62.2 percentage points, on the high side; measured number below the stated range.
By their numbers in this assay, from the lowest: compounds 4, 2 and 1 (each within the scatter of the next); then compound 3.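

The change from methoxycarbonyl to butoxycarbonyl is not neutral in this assay, and its effect depends on the group on the aromatic carbon. With methyl there, it gives a number 66.8 percentage points lower from compound 3 to compound 4 (beyond the scatter), so the earlier small step on the isopropyl compounds does not carry over: the same change on two cores in this assay, a number 3.4 percentage points lower (within the scatter) from compound 1 to compound 2 and a number 66.8 percentage points lower (beyond the scatter) from compound 3 to compound 4, 63.4 percentage points apart, beyond the scatter of two such steps. Likewise, methyl in place of isopropyl now gives only a number 4.3 percentage points lower from compound 2 to compound 4 (within the scatter) when butoxycarbonyl is present, so the earlier gain also depends on the other group: the same change on two cores in this assay, a number 59.1 percentage points higher (beyond the scatter) from compound 1 to compound 3 and a number 4.3 percentage points lower (within the scatter) from compound 2 to compound 4, 63.4 percentage points apart, beyond the scatter of two such steps.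

The compounds shown leave open how an ethoxycarbonyl or propoxycarbonyl group would behave alongside methyl. They also leave open whether an amide in place of the ester would change the picture.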